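Allyl to benzyl in a series without clear steps

A few compounds are considered here, and "the series" means these few. Any claim that something is new, unique, unknown or untested is made for them only; others in the source may bear on it.

compound 1 `CC(=O)Oc1c(Br)cc(Br)cc1Oc1ccc(Br)cc1Br` gives 29.9 ug/mL
compound 2 `BrCCCCCOc1c(Br)cc(Br)cc1Oc1ccc(Br)cc1Br` gives 25.7 ug/mL
compound 3 `C=CCOc1c(Br)cc(Br)cc1Oc1ccc(Br)cc1Br` gives 27.9 ug/mL

In a functional assay on HL-60 cells (Homo sapiens) for cytotoxicity, read by MTT assay, with a stated time of 24 h (on this read-out lower numbers stand for stronger inhibition and higher numbers for weaker inhibition), compound 3 gives 27.9 ug/mL and stands within the scatter of both other compounds, so the three cannot be put in order. Compound 4 `Brc1ccc(Oc2cc(Br)cc(Br)c2OCc2ccccc2)c(Br)c1` keeps the shared core, and its difference from compound 3 is phenyl in place of vinyl on a saturated chain carbon bound to an oxygen on an aromatic ring and, cut one bond further out, reads allyl to benzyl.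

Among the measured compounds shown here, three measured steps bear on this change, all of them at the same oxygen. Putting allyl in place of acetyl gave a 1.1-fold lower number from compound 1 to compound 3 (0.03 log units; within the scatter) and putting 5-bromopentyl in place of acetyl gave a 1.2-fold lower number from compound 1 to compound 2 (0.07 log units; within the scatter) at this oxygen. The change from 5-bromopentyl to allyl gave a 1.1-fold higher number from compound 2 to compound 3 (0.04 log units; within the scatter) and so also stayed within the scatter. For the measured compounds named here, none of the measured groups carries a phenyl, so no measured step shows that group entering, and the evidence is indirect. No step beyond the scatter is therefore expected, and the estimated move is a 1.1-fold lower number from compound 3 to compound 4 (0.03 log units; within the scatter) in this read-out. The estimated value for compound 4 is 26 ug/mL with an expected range from 16 ug/mL to 42 ug/mL for this compound.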

Compound 4, half-maximal inhibitory concentration: 27.9 ug/mL
For compound 4 the middle estimate is 1.1-fold (0.03 log units) below the measured one; the range from low to high includes it.
By their numbers in this assay, from the lowest: compounds 2, 3, 4 and 1 (each within the scatter of the next).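

In this assay, among the compounds shown here, a ring enters at this oxygen for the first time, and phenyl in place of vinyl on the saturated chain carbon gives no change at the digits printed from compound 3 to compound 4 (within the scatter). Set against the other two groups, the same benzyl gives a 1.1-fold higher number from compound 2 to compound 4 (0.04 log units; within the scatter) and a 1.1-fold lower number from compound 1 to compound 4 (0.03 log units; within the scatter), so all three new steps stay within the scatter and the four compounds still cannot be put in order. At this oxygen, then, acetyl, 5-bromopentyl, allyl and now benzyl, which brings one six-membered aromatic ring of carbon only, all give values that cannot be told apart, and nothing shown here offers an explanation for this flat picture.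

The compounds shown leave open whether any group at this oxygen can produce a step beyond the scatter, for instance a chain ending in an amine or a carboxylic acid, or a free hydroxyl in place of the ether. They also leave open whether a change to the shared core, such as chlorine in place of bromine, would move the number when the group on this oxygen does not.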